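Second chloro on the benzyl ring of compound 1

The source may report more compounds than this note shows. Statements on the series, on what has been measured and on what is new or still open speak of the compounds shown alone.

Compound 1 `Nc1cc(OCc2ccccc2Cl)c2nn[nH]c2n1` gives 26 nM in an assay for inhibition of Myeloperoxidase (Homo sapiens), read by Amplex Red, with stated times of 10 min and 15 min; a lower number here means a stronger inhibitor, a higher number a weaker inhibitor. It stands level with compound 3 `Nc1cc(OCc2ccccc2-n2cccn2)c2nn[nH]c2n1`, which gives 26 nM, the two together the lowest of the three numbers; compound 2 `CS(=O)(=O)c1ccccc1COc1cc(N)nc2[nH]nnc12` gives 720 nM, the highest. The measured steps are a 28-fold higher number from compound 1 to compound 2 (1.44 log units; beyond the scatter) and no change at the digits printed from compound 1 to compound 3 (within the scatter), both replacing the chloro outright, and a 28-fold lower number from compound 2 to compound 3 (1.44 log units; beyond the scatter) between the two replacements.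

Compound 4 `Nc1cc(OCc2c(Cl)cccc2Cl)c2nn[nH]c2n1` keeps that chloro and differs from compound 1 by chloro in place of hydrogen on an aromatic carbon, the entering group sitting on an aromatic carbon of a six-membered aromatic ring of carbon only, ortho to a large group and meta to a chloro group. Among the compounds with values here, no measured step adds a group while the chloro remains, so none bears directly on this change. As far as these compounds go, the nearest evidence is that the chloro itself is retained; what the change adds is untested here. The expectation for compound 4 is therefore a step of a 1.3-fold lower number from compound 1 to compound 4 (0.11 log units; within the scatter), inside the scatter, and an estimated value of 20 nM with a range from 8 nM to 60 nM.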

Compound 4, half-maximal inhibitory concentration: 6.7 nM
Beside the measured number, compound 4's estimate is 3.0-fold (0.47 log units) above it; the measured number lies below the stated range.
By their numbers in this assay, from the lowest: compound 4; then compounds 1 and 3 (each within the scatter of the next); then compound 2.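

This carbon, which bears hydrogen in compound 1, takes a second chloro: in this assay the change gives a 3.9-fold lower number from compound 1 to compound 4 (0.59 log units; beyond the scatter) and sets compound 4 at the low end of the series. The earlier steps shown here all replaced the first chloro, ranging from no change to a large rise in the number, whereas this one adds a group while that chloro stays and lowers the number. Nothing measured on these compounds accounts for the step.

Open, as far as these compounds go, is whether a fluoro, a methoxy or an amine on this same carbon would lower the number as chloro does, or whether the step is tied to chloro alone. Also open, from the compounds shown here alone, is whether the same addition carries over to compound 3, which has 1H-pyrazol-1-yl in place of the first chloro.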